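Replacing an Aryl Amide with a Diol Amide

The source may hold more compounds than are shown below. What is called first, only, known or untested is meant among the compounds shown, and "the series" means these compounds.

Three measured compounds share one core. Compound 1 `C#CC(C)OC(=O)c1ccc(C(CC)(CC)c2ccc(OCCC(O)(CC)CC)c(C)c2)n1CC` carries a (1-methylprop-2-yn-1-yl)oxy group on its carbonyl carbon, compound 2 `CCn1c(C(=O)Nc2ccc(OC(F)(F)F)cc2)ccc1C(CC)(CC)c1ccc(OCCC(O)(CC)CC)c(C)c1` an amide to a (4-(trifluoromethoxy)phenyl)amino group, and compound 3 `CCn1c(C(=O)NC(CC(=O)O)C(=O)OC)ccc1C(CC)(CC)c1ccc(OCCC(O)(CC)CC)c(C)c1` an amide to an open-chain acid ester. In a functional assay on HepG2 cells (Homo sapiens) for antiproliferative activity, read by MTT assay, with a stated time of 48 h (a higher number here means a weaker inhibitor, a lower number a stronger inhibitor), compound 1 gives > 50000 nM, which is a limit of the assay and not a number. Compound 2 likewise gives only a limit, > 50000 nM. Compound 3 gives a measured number, 10700 nM. Both limits are the limit of > 50000 nM in this assay, at which 2 of the 3 values shown sit, so a step that the two limits leave unreadable from compound 1 to compound 2, whereas an at least 4.6-fold lower number from compound 1 to compound 3 (0.66 log units; beyond the scatter) and an at least 4.6-fold lower number from compound 2 to compound 3 (0.66 log units; beyond the scatter) are at least modest moves toward stronger inhibition.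

Compound 4 `CCn1c(C(=O)NC(CO)CCO)ccc1C(CC)(CC)c1ccc(OCCC(O)(CC)CC)c(C)c1` is not yet measured. It differs from compound 2 in one place: 3-hydroxy-1-(hydroxymethyl)propyl in place of 4-(trifluoromethoxy)phenyl on an amide-type nitrogen. The closest guide is an at least 4.6-fold lower number from compound 2 to compound 3 (0.66 log units; beyond the scatter), which also swapped the aryl amide for a small open-chain group and gave at least a modest drop. Compound 4 is therefore expected to leave the limit, with an estimate of 15000 nM and a range from 5000 nM to 50000 nM. The expected step is an at least 3.3-fold lower number from compound 2 to compound 4 (0.52 log units; beyond the scatter), a modest move toward stronger inhibition, and the measurement will show whether it follows.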

Compound 4, half-maximal inhibitory concentration: 24800 nM
Compound 4: middle estimate off by 1.7-fold (0.22 log units), on the low side; measured number inside the range.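

Compound 4 gives a second measured number in this assay with an open-chain group on the amide-type nitrogen, so a measured value here does not need the acid ester of compound 3. The open-chain groups also differ from each other, and that difference can be read: a 2.3-fold higher number from compound 3 to compound 4 (0.37 log units; beyond the scatter), so the choice of chain at this position changes the result. Going by these compounds alone, the gain over the earlier compounds is less secure, as an at least 2.0-fold lower number from compound 2 to compound 4 (0.30 log units; that floor lies within the scatter) and an at least 2.0-fold lower number from compound 1 to compound 4 (0.30 log units; that floor lies within the scatter) give only floors that lie within the scatter, and their true sizes stay hidden because compounds 1 and 2 sit at a limit: the limit of > 50000 nM in this assay, at which 2 of the 4 values shown sit.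

As far as these compounds go, it remains open whether the measured number in compound 4 comes from losing the 4-(trifluoromethoxy)phenyl ring or from gaining the hydroxyl groups of the 3-hydroxy-1-(hydroxymethyl)propyl chain, as the swap changes both at once. An amine in place of a hydroxyl, or a longer chain carrying the same hydroxyl groups, would help to separate these two readings.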